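A few compounds are considered here, and "the series" means these few. Any claim that something is new, unique, unknown or untested is made for them only; others in the source may bear on it.

Compound 1 `O=C(CCCCCNC(=S)N/N=C(\c1ccccc1)c1ccccn1)NO`: 2030 nM
Compound 2 `O=C(CCCCCNC(=S)NN=C(c1ccccc1)c1ccccc1)NO`: 3640 nM

In a functional assay on K562/A02 cells (Homo sapiens) for antiproliferative activity, read by MTT assay (on this read-out higher numbers stand for weaker inhibition and lower numbers for stronger inhibition), compound 2 gives 3640 nM, and this number lies within the usual scatter of compound 1 at 2030 nM, so the two cannot be told apart. Compound 3 `Cc1ccccc1/C(=N/NC(=S)NCCCCCC(=O)NO)c1ccccc1` departs from compound 2 by one change, methyl in place of hydrogen on an aromatic carbon. Among the measured compounds shown here, no measured pair shows what such a change does, so no direction is favoured, and only a small shift, none beyond the scatter, is expected. The expected move is a 1.1-fold lower number from compound 2 to compound 3 (0.04 log units; within the scatter). For compound 3 the estimated value is 3300 nM, with an expected range of 1500 nM to 7000 nM.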

Compound 3, half-maximal inhibitory concentration: 4220 nM
For compound 3 the middle estimate is 1.3-fold (0.11 log units) below the measured one; the measured number falls inside the stated range.
By their numbers in this assay, from the lowest: compounds 1, 2 and 3 (each within the scatter of the next, the first and the last beyond it).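

In this assay, among the compounds shown here, methyl in place of hydrogen on an aromatic carbon, ortho to a large group, gives a 1.2-fold higher number from compound 2 to compound 3 (0.06 log units; within the scatter), so compound 3 cannot be told apart from compound 2. 2-Methylphenyl in place of pyridin-2-yl gives a 2.1-fold higher number from compound 1 to compound 3 (0.32 log units; beyond the scatter), the only single-place step here that passes the scatter, and it is modest. Nothing available explains either step. As far as these compounds go, whether a methoxy group or an amine on this same aromatic carbon would give a number beyond the scatter remains open, as does the effect of a longer chain.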